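A few compounds are considered here, and "the series" means these few. Any claim that something is new, unique, unknown or untested is made for them only; others in the source may bear on it.

Working notes on the series, a set of dihydropyridine esters with an aryl group on the ring nitrogen, read in a functional assay for inhibition, using microsomes, tested at 100 ug/mL; a higher number here means a weaker effect of the compound at the concentration tested, a lower number a stronger effect.

Compound 1 `CCOC(=O)C1=C(C)N(c2ccc(C)cc2)C=CC1c1ccccc1` gives -23.5% in this assay. For the measured compounds named here, compound 2 `CCOC(=O)C1=C(C)N(c2ccc(F)cc2)C=CC1c1ccccc1` gives -28.5% in this assay, and the only single-place step among the measured compounds is a number 5 percentage points lower from compound 1 to compound 2 (within the scatter). Compound 3 `COC(=O)C1=C(C)N(c2ccc(OC)cc2)C=C(C)C1c1ccccc1` gives -14.7% in this assay, the highest of the three numbers; its nearest neighbour is compound 1, whose number is lower but within the scatter, and its furthest is compound 2, whose number is lower by more than the scatter. Going by the values given here, compound 3 differs from compounds 1 and 2 in more than one place, so no single step is drawn between them.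

Compound 4 `COC(=O)C1=C(C)N(c2cccc(C)c2C)C=C(C)C1c1ccccc1` is not yet measured. It differs from compound 3 in one place: 2,3-dimethylphenyl in place of 4-methoxyphenyl on an amine nitrogen in a ring. Among the compounds with values here, the one step that bears on this is the change of the aryl group on the amine nitrogen from compound 1 to compound 2, which was within the scatter. No step beyond the scatter is therefore expected in this assay for the exchange of the aryl group here. Compound 4 is estimated to give -18% in this assay, with a range from -38% to 2%. This estimate amounts to an expected step of a number 3.3 percentage points lower from compound 3 to compound 4 (within the scatter), within the scatter.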

Compound 4, a percentage reported as activity, at one concentration (the size of the read-out at that concentration, not a potency): -22.7%
The estimate for compound 4 lay 4.7 percentage points above the measured number; the range from low to high includes it.
By their numbers in this assay, from the lowest: compounds 2, 1, 4 and 3 (each within the scatter of the next, the first and the last beyond it).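

On the core of compound 3, the exchange of 4-methoxyphenyl for 2,3-dimethylphenyl on the amine nitrogen in the ring comes out as a number 8 percentage points lower from compound 3 to compound 4 (within the scatter) in this assay and so carries the reading of this position over to a second core and to a wider change of the aryl group than the swap of one substituent. Together with a number 5 percentage points lower from compound 1 to compound 2 (within the scatter) this makes two exchanges at this nitrogen that stay within the scatter, even though here the leaving group has a hydrogen-bond acceptor and the entering group has none. No measurement in hand bears on why this exchange reads as it does.

The aryl groups shown carry only methyl, fluoro or methoxy, so an aryl group bearing an amine or a carboxylic acid, or a longer alkyl chain in place of the aryl group on this nitrogen, remains open. Also open, as far as these compounds go, is whether any exchange here can move the number beyond the scatter, and what these numbers mean for potency, since each is a read-out at one concentration.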